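The compounds below may be only part of what the source reports. "The series", "measured", "known", "first", "only" and "open" are said of these compounds alone.

In a physicochemical assay for lipophilicity, using the shake flask method, in phosphate buffer, measured as octanol-water partition, at pH 7.4 (a lower number here means a more polar compound, a higher number a more lipophilic compound), compound 3 `CC[C@@H](c1ccc(C(=O)O)c(Oc2cccc(Cl)c2)c1)N1CCC[C@H](n2cc(C)c(=O)[nH]c2=O)C1` gives 0.22. Two close relatives offer a comparison: compound 1 `CC[C@@H](c1ccc(C(=O)O)c(Oc2cccc(Cl)c2)c1F)N1CCC[C@H](n2cc(C)c(=O)[nH]c2=O)C1` gives 0.11, and compound 2 `CCC[C@@H](c1ccc(C(=O)O)c(Oc2cccc(Cl)c2)c1OC)N1CCC[C@H](n2cc(C)c(=O)[nH]c2=O)C1` gives 0.13. All three numbers lie within the usual scatter of one another, so compound 3 cannot be separated from either relative on this measure.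

Compound 4 `CC[C@@H](c1ccc(C(=O)O)c(Oc2cccc(Cl)c2)c1OC)N1CCC[C@H](n2cc(C)c(=O)[nH]c2=O)C1` differs from compound 3 in a single place: methoxy in place of hydrogen on an aromatic carbon. In words, this is methoxy in place of hydrogen on an aromatic carbon, ortho to a 3-chlorophenoxy group and meta to a carboxy group.

Among the measured compounds shown here, only one measured step involves a single swap on an aromatic carbon: a number 0.11 log units higher from compound 1 to compound 3 (within the scatter). That step stays within the scatter, but it involves fluoro rather than methoxy, so it is only indirect evidence. Compound 2 also carries a methoxy group and gives 0.13, but it has a propyl chain where compound 4 has an ethyl chain. For the measured compounds named here, no measured step isolates that chain difference, so compound 2 is only a loose guide.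

The expected change is small and slightly downward, with no shift beyond the scatter: an estimated a number 0.17 log units lower from compound 3 to compound 4 (within the scatter). The estimate for compound 4 is 0.05, with an expected range from -0.3 to 0.35.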

Compound 4, distribution coefficient: -0.02
Compound 4: middle estimate off by 0.07 log units, on the high side; measured number inside the range.
By their numbers in this assay, from the lowest: compounds 4, 1, 2 and 3 (each within the scatter of the next).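

In this assay the swap of hydrogen for methoxy on an aromatic carbon, ortho to a 3-chlorophenoxy group and meta to a carboxy group, now has a direct reading (a number 0.24 log units lower from compound 3 to compound 4 (within the scatter)), and it stays within the scatter. Methoxy in place of fluoro on that same carbon gives a similar picture (a number 0.13 log units lower from compound 1 to compound 4 (within the scatter)), so with an ethyl chain in place, hydrogen, fluoro and methoxy at this position cannot be told apart on this measure. The chain difference that made compound 2 only a loose guide can now be read as well: hydrogen in place of methyl on the saturated chain also stays within the scatter (a number 0.15 log units lower from compound 2 to compound 4 (within the scatter)), so this change does not separate the two methoxy compounds either.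

Going by these compounds, it remains open whether a larger or differently charged group on this aromatic carbon, such as an amine or a carboxylic acid, would move the number beyond the scatter. Nothing given here offers an explanation for these small differences.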